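Methoxy in place of methyl on a fused aromatic core

The compounds below may be only part of what the source reports. "The series", "measured", "known", "first", "only" and "open" are said of these compounds alone.

Measured compounds:
compound 1, `Cc1onc(-c2ccc(Cl)cc2Cl)c1C(=O)/N=c1/nc2nc(Cl)cc(C)n2s1`, 73.6%
compound 2, `Cc1cc(C)nc(NC(=S)NC(=O)c2c(-c3ccc(Cl)cc3Cl)noc2C)n1`, 65.4%

Of the compounds shown here, two have been measured in a functional assay on the whole organism for inhibition, with Chenopodium ficifolium as the target, with a stated time of 72 h, tested at 100 mg/L; a lower number here means less inhibition of growth, a higher number more inhibition of growth at the concentration tested. Compound 1 gives 73.6% in this assay, and compound 2 gives 65.4%. Compound 1 has the higher of the two numbers, but the gap to compound 2 lies within the usual scatter of repeated measurements, so the two values cannot be told apart with confidence.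

Compound 3, `COc1cc(Cl)nc2n/c(=N/C(=O)c3c(-c4ccc(Cl)cc4Cl)noc3C)sn12`, has not yet been measured in this assay. It differs from compound 1 in one place: methoxy in place of methyl on an aromatic carbon. Among the measured compounds shown here, no pair of measured compounds differs in this way. For the measured compounds named here, nothing among the measured compounds therefore shows what such a swap does here. Without such a reference, the most cautious expectation is a change that stays within the scatter, in either direction.

For compound 3 the expected step from compound 1 is a number 3.6 percentage points lower from compound 1 to compound 3 (within the scatter). Compound 3 is therefore estimated at 70% in this assay, with a likely range from 50% to 88%.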

Compound 3, percent growth inhibition at one concentration: 65.9%
Compound 3: the middle estimate sits 4.1 percentage points above what was measured; measured number inside the range.
By their numbers in this assay, from the lowest: compounds 2, 3 and 1 (each within the scatter of the next).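

In this assay, methoxy in place of methyl on this aromatic carbon, next to the ring nitrogen, amounts to a number 7.7 percentage points lower from compound 1 to compound 3 (within the scatter), so this first direct test of the swap gives two numbers that cannot be told apart. The position therefore takes the larger methoxy, with its added oxygen, without a change that can be read in this pair, and compound 3 still gives 65.9%. Nothing reported alongside these numbers speaks to what lies behind this result.

This is a single pair, tested at a single concentration, so it cannot show whether the two compounds would also stay together at lower doses, or whether the same swap would behave alike on another core. It also leaves open whether an amine or a longer chain such as ethoxy on this same carbon would stay within the scatter of compound 1, or whether the tolerance seen here is limited to methyl and methoxy.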